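Swapping a Benzofuran for a Methoxyphenyl Group

The compounds below may be only part of what the source reports. "The series", "measured", "known", "first", "only" and "open" are said of these compounds alone.

Of the compounds shown here, two have been measured in an assay on CHO-K1 cells for antagonist activity at adenosine receptor A1 (Homo sapiens), read by a beta-galactosidase reporter, with stated times of 15 min and 6 h; a higher number here means a weaker inhibitor, a lower number a stronger inhibitor. Compound 1 `CN(C)Cc1cc2c(N)nc(-c3ccco3)nc2s1` gives 3550 nM in this assay. Compound 2 `Nc1nc(-c2cc3ccccc3o2)nc2sc(CN3CCC(F)CC3)cc12` gives 630 nM in this assay, the lower of the two numbers, and the gap to compound 1 lies beyond the usual scatter. Compound 3 `COc1cccc(-c2nc(N)c3cc(CN4CCC(F)CC4)sc3n2)c1` has not been measured yet. It differs from compound 2 in one place: 3-methoxyphenyl in place of 1-benzofuran-2-yl on an aromatic carbon. Within the data shown here, no measured pair shows this particular change on its own, so its effect cannot be read off directly. Compound 1 and compound 2 differ in two places at once, so their values say nothing clean about the group in this position. The step of a 2.4-fold higher number from compound 2 to compound 3 (0.38 log units; beyond the scatter) is expected to run toward a higher number, though it may well stay within the scatter. Compound 3 is therefore estimated at 1500 nM, with a range from 400 nM to 6000 nM.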

Compound 3, inhibition constant: 3220 nM
Compound 3: the middle estimate sits 2.1-fold (0.33 log units) below what was measured, and the stated range covers the measured number.
By their numbers in this assay, from the lowest: compound 2; then compounds 3 and 1 (each within the scatter of the next).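

Among these compounds, replacing 1-benzofuran-2-yl with 3-methoxyphenyl gives a 5.1-fold higher number from compound 2 to compound 3 (0.71 log units; beyond the scatter) in this assay and, with only this group changed, offers the first clean reading of this position. The group on the aromatic carbon between two ring nitrogen atoms therefore influences the number, even though both groups have the same printed counts of hydrogen-bond donors and acceptors and carry no net charge. No separate measurement bears on the reason for this step.

The compounds shown leave open whether the step follows from losing the five-membered ring of the benzofuran or from adding the methoxy group, a question that an unsubstituted phenyl group at this position could help separate. As far as these compounds go, it also remains open how a pyridine ring or a 3-hydroxyphenyl group would compare on the same core.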